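Replacing a Sulfur-Bearing Group on a Longer Chain

The source may hold more compounds than are shown below. What is called first, only, known or untested is meant among the compounds shown, and "the series" means these compounds.

Compound 1, with structure `CC/N=C(\S)NCCCCCn1nc(-c2ccccc2)ccc1=O`, was tested in a functional assay on the whole organism with Rattus norvegicus as the target, at a dose of 100 mg/kg (a higher number here means more inhibition at the dose given (going by the name of the read-out), a lower number less inhibition), where compound 1 gives 66.4%. Among the compounds with values here, this is the higher of the two numbers measured so far, but only narrowly: compound 2, with structure `CC/N=C(/NC#N)NCCCn1nc(-c2ccccc2)ccc1=O`, gives 62.9% in this assay, and the step of a number 3.5 percentage points lower from compound 1 to compound 2 (within the scatter) lies within the scatter. That step replaces a group containing sulfur with one containing a nitrile, on the chain three bonds along from an aromatic nitrogen.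

Compound 3, with structure `CN(C)/C(=N/CCCCCn1nc(-c2ccccc2)ccc1=O)NC#N`, has not yet been measured. It differs from compound 1 as follows: a group of 8 heavy atoms (4 carbon, 4 nitrogen; no ring) in place of a group of 6 heavy atoms (3 carbon, 2 nitrogen, 1 sulfur; no ring), on a saturated chain carbon, five bonds along the chain from an aromatic nitrogen. The group that enters is of the same kind as the one that entered in the step from compound 1 to compound 2, though here the chain is longer and the group that leaves is smaller. Within the data shown here, since the only comparable step, a number 3.5 percentage points lower from compound 1 to compound 2 (within the scatter), stayed within the scatter, no step beyond the scatter is expected in this assay. The estimated value for compound 3 is 63%, with a range from 48% to 78%, which corresponds to an expected step of a number 3.4 percentage points lower from compound 1 to compound 3 (within the scatter).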

Compound 3, a percentage reported as inhibition, in the whole organism at one dose (the size of the read-out at that dose, not a potency): 63.9%
Estimate against measurement, compound 3: 0.9 percentage points below; the measured number falls inside the stated range.
By their numbers in this assay, from the lowest: compounds 2, 3 and 1 (each within the scatter of the next).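

Compound 3 keeps the place of attachment of compound 1, five bonds along the chain from an aromatic nitrogen, so it tests the exchange of the sulfur-bearing group for the nitrile-bearing group at this position alone. In this assay, the result is a number 2.5 percentage points lower from compound 1 to compound 3 (within the scatter), so the two compounds cannot be told apart at this single dose, even though the entering group is larger and carries a different mix of hydrogen-bond donors and acceptors. Together with the earlier step, this means the sulfur atom is not needed for a number of this size at this position, but nothing available here explains why the two groups read alike.

Because the read-out comes from one dose in whole animals, it leaves open whether the compounds would still read alike at other doses, and it gives no measure of potency. It also leaves open whether a simple amine or a carboxylic acid in place of these groups, or a longer chain carrying the nitrile-bearing group, would stay within the scatter of compound 1.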